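The source may report more compounds than this note shows. Statements on the series, on what has been measured and on what is new or still open speak of the compounds shown alone.

Working notes on the series, all read in a functional assay on MDA-MB-231 cells (Homo sapiens) for antiproliferative activity, read by MTT assay, with a stated time of 72 h; a lower number here means a stronger inhibitor, a higher number a weaker inhibitor. Compound 1 `NC1=NC2(CCOCC2)N(OCCCOc2ccccc2)C(N)=N1` stands at "not determined" (no result reported), and compound 2 `COc1ccc(OCCCON2C(N)=NC(N)=NC23CCOCC3)cc1` stands at "not determined" (no result reported). Compound 3 `NC1=NC2(CCOCC2)N(OCCCOc2cccc(Cl)c2Cl)C(N)=N1` gives 140 nM. Going by the values given here, this is the only number so far, so compound 3 has no rank and serves as the single reference point.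

Compound 4 `NC1=NC2(CCOCC2)N(OCCCOc2ccccc2Cl)C(N)=N1` goes from 2,3-dichlorophenyl to 2-chlorophenyl on the same core: hydrogen in place of chloro on an aromatic carbon. In words, this is hydrogen in place of chloro on an aromatic carbon, and one chloro group stays on the ring.

Among the compounds with values here, no measured step between close neighbours is available to size this change. The expectation therefore rests only on the value of compound 3, 140 nM, and on the structural difference, and it carries a wide margin. A modest weakening in this assay is expected, not far beyond the scatter, with the estimated step being a 1.8-fold higher number from compound 3 to compound 4 (0.25 log units; within the scatter). The estimate for compound 4 is 250 nM, with an expected range of 70 nM to 900 nM.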

Compound 4, half-maximal inhibitory concentration: 1430 nM
Beside the measured number, compound 4's estimate is 5.7-fold (0.76 log units) below it; the measured number lies above the stated range.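

In this assay, going by these compounds alone, the change of hydrogen in place of chloro on an aromatic carbon gives a 10-fold higher number from compound 3 to compound 4 (1.01 log units; beyond the scatter) and so supplies the first measured step. This carbon, ortho to a chloro group and meta to a large group, is therefore a sensitive position: the loss of 1 heavy atom is enough to produce a large step. The chloro that stays in the 2-chlorophenyl group of compound 4 does not preserve the number of the 2,3-dichlorophenyl group of compound 3.

Open, as far as these compounds go, are whether fluoro, bromo or methyl on this carbon would hold the number of compound 3, and how far removal of the remaining chloro would carry it, as compound 1 has no number. Nothing measured here gives a reason for the size of this step.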